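The source may report more compounds than this note shows. Statements on the series, on what has been measured and on what is new or still open speak of the compounds shown alone.

Measured compounds:
compound 1 `CN(C)C(=O)c1cccc(C#Cc2cc(Cl)ccc2OCC(=O)O)c1` with 52 nM
compound 2 `Cc1ccc(S(=O)(=O)Cc2ccccc2)cc1C#Cc1cc(Cl)ccc1OCC(=O)O` with 5 nM
compound 3 `CCS(=O)(=O)c1ccc(C)c(C#Cc2cc(Cl)ccc2OCC(=O)O)c1` with 8.6 nM

All three were tested in an assay on CHO cells for displacement of a labelled ligand from prostaglandin D2 receptor 2 (Homo sapiens), read by scintillation counting; a lower number here means a stronger inhibitor, a higher number a weaker inhibitor. Compound 3 holds the second highest of the three numbers; it sits close to compound 2, from which a 1.7-fold higher number from compound 2 to compound 3 (0.24 log units; within the scatter), and far from compound 1, whose number is higher and beyond the scatter. Compound 1 lacks a sulfonyl group altogether, so its gap to compound 3 is a comparison of two values only, not a single-change step.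

Compound 4 `CNS(=O)(=O)c1ccc(C)c(C#Cc2cc(Cl)ccc2OCC(=O)O)c1` has not yet been measured. It differs from compound 3 in one place: methylamino in place of ethyl on a sulfonyl sulfur. Going by the values given here, the only measured step that bears on a change at the sulfonyl sulfur is the one from compound 2 to compound 3, where a swap of the group on that sulfur left the number within the scatter. Among the compounds with values here, that step suggests the sulfonyl substituent can be varied without a large shift in this assay, though the entering methylamino group brings a hydrogen-bond donor that no measured compound carries, so no step here is a direct precedent.

Compound 4 is therefore expected to stay near compound 3, with a 1.4-fold higher number from compound 3 to compound 4 (0.14 log units; within the scatter) and a value estimated at 12 nM, between 4 nM and 36 nM.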

Compound 4, inhibition constant: 10 nM
Compound 4: the middle estimate sits 1.2-fold (0.08 log units) above what was measured; the range from low to high includes it.
By their numbers in this assay, from the lowest: compounds 2, 3 and 4 (each within the scatter of the next); then compound 1.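

In this assay, going by these compounds alone, the sulfonyl sulfur takes methylamino in place of ethyl with a 1.2-fold higher number from compound 3 to compound 4 (0.07 log units; within the scatter), which shows for the first time that a group bearing a hydrogen-bond donor can stand there without a shift beyond the scatter. Methylamino in place of benzyl on that sulfur gives a 2.0-fold higher number from compound 2 to compound 4 (0.30 log units; within the scatter), so ethyl, benzyl and methylamino all give numbers within the scatter of one another in these compounds. No evidence is available to explain this result.

From the compounds shown here alone, whether the hydrogen on the methylamino nitrogen has any bearing on the value remains open, and a dimethylamino group or a plain amino group on the sulfur would address that. How a longer chain such as propyl, or a ring amine such as morpholine, would behave at this sulfur is also left open.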